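A Primary Amine Replacing the Hydroxyl on the Amide Chain

The compounds below may be only part of what the source reports. "The series", "measured", "known", "first", "only" and "open" are said of these compounds alone.

Measured compounds:
- compound 1, `CC(C)(C)c1ccc(C(=O)N2CCC3(CC2)C(=O)N(CC(=O)N2CCC(CCO)CC2)CN3c2ccccc2)cc1`, 2600 nM
- compound 2, `CC(C)(C)c1ccc(C(=O)N2CCC3(CC2)C(=O)N(CC(=O)NCCO)CN3c2ccccc2)cc1`, 1000 nM
- compound 3, `O=C(CN1CN(c2ccccc2)C2(CCN(C(=O)c3ccc(C4CCCCC4)cc3)CC2)C1=O)N1CCCCC1`, 1100 nM

In an assay on HEK293 cells for displacement of a labelled ligand from NPC1-like intracellular cholesterol transporter 1 (Homo sapiens) (a lower number here means a stronger inhibitor, a higher number a weaker inhibitor), compound 2 gives the lowest of the three numbers. Its nearest neighbour is compound 3, which lies within the scatter of it, while compound 1 sits furthest away: the change a 2.6-fold lower number from compound 1 to compound 2 (0.41 log units; beyond the scatter) is modest but beyond the scatter.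

Compound 4, `CC(C)(C)c1ccc(C(=O)N2CCC3(CC2)C(=O)N(CC(=O)NCCCN)CN3c2ccccc2)cc1`, has not yet been measured. It differs from compound 2 by aminomethyl in place of hydroxy on a saturated chain carbon, two bonds along the chain from an amide-type nitrogen.

Among the compounds with values here, none of the measured steps touches this change. Within the data shown here, the one step that is known, from compound 1 to compound 2, exchanges the whole amide substituent rather than one group at the end of the chain, and compound 3 carries a different acyl group and a different amide, so it gives no guide either. With nothing bearing directly on the exchange, no step beyond the scatter is expected.

Compound 4 is therefore estimated at 900 nM, with a range from 300 nM to 3000 nM, a step of a 1.1-fold lower number from compound 2 to compound 4 (0.05 log units; within the scatter) that is expected to stay within the scatter.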

Compound 4, half-maximal inhibitory concentration: 4200 nM
For compound 4 the middle estimate is 4.7-fold (0.67 log units) below the measured one; measured number above the stated range.
By their numbers in this assay, from the lowest: compounds 2 and 3 (each within the scatter of the next); then compounds 1 and 4 (each within the scatter of the next).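

In this assay, the end of this chain proves sensitive to the exchange: aminomethyl in place of hydroxy, on a saturated chain carbon two bonds along the chain from an amide-type nitrogen, gives a 4.2-fold higher number from compound 2 to compound 4 (0.62 log units; beyond the scatter). The gain seen for the (2-hydroxyethyl)amino group of compound 2 does not carry over to the (3-aminopropyl)amino group, since a 1.6-fold higher number from compound 1 to compound 4 (0.21 log units; within the scatter) leaves compound 4 no different from compound 1 within the scatter. No measurement shown here explains this rise in the number.

The exchange alters both the end group and the chain length, so the compounds shown do not separate the two. A (2-aminoethyl)amino group would place the amine on the shorter chain, and a (3-hydroxypropyl)amino group would keep the hydroxy on the longer one.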